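Cutting Back the Amine End of Compound 1

The source may report more compounds than this note shows. Statements on the series, on what has been measured and on what is new or still open speak of the compounds shown alone.

Two compounds sharing one core and a long ether-linked side chain have so far been measured in an assay on isolated protein (Cavia porcellus) with Sigma non-opioid intracellular receptor 1 (Homo sapiens) as the target, read by radioligand binding; on this read-out higher numbers stand for weaker inhibition and lower numbers for stronger inhibition. Compound 1 `CN(C)CCCCCCCOc1ccc2oc(-c3ccccc3)cc(=O)c2c1` gives 188 nM in this assay, the lowest of the two numbers. Compound 2 `O=c1cc(-c2cccnc2)oc2ccc(OCCCCCCN3CCC(O)CC3)cc12` gives 210 nM in this assay, a number within the scatter of that of compound 1, so the two cannot be told apart here. Compound 3 `NCCCCCCOc1ccc2oc(-c3ccccc3)cc(=O)c2c1` has not yet been measured. It differs from compound 1 in a single place: amino in place of (dimethylamino)methyl on a saturated chain carbon, six bonds along the chain from an oxygen on an aromatic ring. Within the data shown here, no measured pair shows what such a change does, so the expectation rests on the structural change alone. For compound 3 the expected step, in the direction of weaker inhibition, is estimated as a 4.3-fold higher number from compound 1 to compound 3 (0.63 log units; beyond the scatter). Compound 3 is therefore estimated at 800 nM in this assay, with a range from 200 nM to 3000 nM.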

Compound 3, half-maximal inhibitory concentration: 3700 nM
For compound 3 the middle estimate is 4.6-fold (0.67 log units) below the measured one; the measured number lies above the stated range.
By their numbers in this assay, from the lowest: compounds 1 and 2 (each within the scatter of the next); then compound 3.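

In this assay, replacing (dimethylamino)methyl with amino gives a 20-fold higher number from compound 1 to compound 3 (1.29 log units; beyond the scatter), a large step beyond the scatter, so this end of the side chain does not tolerate every change. Among these compounds, the single swap does two things at once: it shortens the chain and removes the methyl groups from the nitrogen, and the step reports only their combined result. Nothing available here explains why inhibition weakens.

From the compounds shown here alone, how much of the step belongs to the shorter chain and how much to the lost methyl groups remains open. A dimethylamino group on the shorter chain of compound 3, or an amino group on the longer chain of compound 1, would separate the two, and a methylamino group would show whether a single methyl group is enough.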